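The source may hold more compounds than are shown below. What is called first, only, known or untested is meant among the compounds shown, and "the series" means these compounds.

Measured compounds in an ADME assay on BJ cells (Homo sapiens) for cytotoxicity, read by CellTiter-Glo and resazurin assay, with a stated time of 72 h; a lower number here means that less compound is needed, a higher number that more compound is needed for the effect:
Compound 1 `CC(C)Oc1cccc(-c2ccc(C(=O)N(Cc3cccc(OCCCCCC(=O)O)c3)C(C)C)cc2)c1` gives > 26000 nM, a limit of the assay rather than a number.
Compound 2 `CC(C)N(Cc1cccc(OCCCCCC(=O)O)c1)C(=O)c1ccc(-c2ccc3c(c2)OCCO3)cc1` gives > 21900 nM, also a limit.
Compound 3 `CC(C)N(Cc1cccc(OCCCCCC(=O)O)c1)C(=O)c1ccc(-c2cccc(C(F)(F)F)c2)cc1` gives > 26000 nM, again a limit.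

Compound 3 thus stands only at a limit in this assay, and so do the two other compounds shown. All three share the same core and differ only in the group carried on one aromatic ring of that core. The steps among them, a step that the two limits leave unreadable from compound 1 to compound 2, a step that the two limits leave unreadable from compound 1 to compound 3 and a step that the two limits leave unreadable from compound 2 to compound 3, cannot be read in size because the limit of > 26000 nM in this assay, at which 2 of the 3 values shown sit, and the limit of > 21900 nM in this assay, at which 1 of the 3 values shown sits, mark both ends of every one of them. Compound 4 `CC(C)N(Cc1cccc(OCCCCCC(=O)O)c1)C(=O)c1ccc(-c2cccc(Br)c2)cc1` is not yet measured; it differs from compound 3 by bromo in place of trifluoromethyl on an aromatic carbon. Nothing measured bears on this change beyond the three limits. The step that the limit leaves unreadable from compound 3 to compound 4 is therefore expected to be none beyond the scatter, with the result most likely reported once more as a limit. Compound 4 is expected to give 40000 nM in this assay, within 15000 nM to 150000 nM.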

Compound 4, half-maximal effective concentration: > 26000 nM
Compound 4 was reported as a limit; the forecaster's own chance of this, stated with the estimate: 85%; the middle value does not contradict the limit.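

For the compounds shown here, compound 4 stands at a limit in this assay, like compound 1, compound 2 and compound 3, and no step from any of these to compound 4 can be read in size. The compounds shown leave open at what concentration, if any, each reaches the half-maximal effect, and whether the group changed on the aromatic ring matters at all.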